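The source may hold more compounds than are shown below. What is called first, only, known or untested is meant among the compounds shown, and "the series" means these compounds.

Measured so far:
compound 1, `CCN(c1nc(C)cc(C)n1)c1ccc(N(C)C)cc1C`, in an assay on isolated protein for binding affinity to corticotropin-releasing factor receptor 1 (Homo sapiens) (a lower number here means a stronger inhibitor, a higher number a weaker inhibitor), gives 54 nM;
compound 2, `CCN(CC)c1cc(C)nc(N(CC)c2ccc(N(C)C)cc2C(F)(F)F)n1`, in this assay gives 11 nM.

Compound 2 stands with the lowest number of the two, and its gap to compound 1 lies beyond the usual scatter of repeated measurements, so compound 2 is the stronger binder of the pair. The step to the still unmeasured compound 3, `CCN(c1nc(C)cc(C)n1)c1ccc(N(C)C)cc1C(F)(F)F`, changes one place on the shared core: methyl in place of diethylamino on an aromatic carbon. Within the data shown here, no measured pair shows this particular change, so its effect can only be guessed from the size of the group that leaves against the one that enters. A moderate weakening, beyond the scatter, is expected, since a five-atom group gives way to a single carbon. In this assay compound 3 is therefore estimated at 30 nM, with a plausible range from 10 nM to 100 nM. The expected step from compound 2 to compound 3 is a 2.7-fold higher number from compound 2 to compound 3 (0.44 log units; beyond the scatter).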

Compound 3, inhibition constant: 68 nM
Estimate against measurement, compound 3: 2.3-fold (0.36 log units) below, and the stated range covers the measured number.
By their numbers in this assay, from the lowest: compound 2; then compounds 1 and 3 (each within the scatter of the next).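

In this assay, replacing diethylamino with methyl on the aromatic carbon next to the ring nitrogen gives a 6.2-fold higher number from compound 2 to compound 3 (0.79 log units; beyond the scatter), so the group at this position clearly matters, and here the larger group goes with the stronger binding. The other single change, trifluoromethyl in place of methyl on an aromatic carbon, gives a 1.3-fold higher number from compound 1 to compound 3 (0.10 log units; within the scatter), so compound 1 and compound 3 cannot be told apart in binding, at least while methyl holds the first position. No measurement shown here explains why diethylamino outdoes methyl.

Still open, going by these compounds, is whether the nitrogen or the ethyl chains of diethylamino carry the gain, which a plain amine, dimethylamino or a longer chain such as dipropylamino at this position could separate. On these data alone, the trifluoromethyl swap is also read only alongside methyl, so its size next to diethylamino remains unknown.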